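A trifluoromethyl swap at the assay limit

The source may hold more compounds than are shown below. What is called first, only, known or untested is meant among the compounds shown, and "the series" means these compounds.

In a functional assay on NCI-H1299 cells (Homo sapiens) for inhibition, with a stated time of 48 h, at 37 degrees C (a higher number here means a weaker inhibitor of growth, a lower number a stronger inhibitor of growth), compound 2 (`Clc1ccc(-c2noc(-c3occc3Br)n2)cc1`) gives > 10000 nM and this is a limit, not a number. Compound 1 (`Clc1ccc(-c2noc(-c3sccc3Cl)n2)nc1`) gives > 10000 nM which is likewise a limit. Compound 3 (`Clc1ccc(-c2noc(-c3occc3Cl)n2)cc1`) gives > 10000 nM which is also a limit. The whole set therefore rests on the limit of > 10000 nM in this assay, at which 3 of the 3 values shown sit, and compound 2 has no measured rank within it.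

The next compound, compound 4 (`FC(F)(F)c1ccc(-c2noc(-c3occc3Br)n2)cc1`), keeps the rest of compound 2 and carries trifluoromethyl in place of chloro on an aromatic carbon, para to a large group (trifluoromethyl in place of chloro on an aromatic carbon). Among the measured compounds shown here, the only measured step is a step that the two limits leave unreadable from compound 2 to compound 3 and it exchanges bromo for chloro at a different place. It offers no size and no direction to carry over, so no change beyond the scatter is expected in this assay. The expected change is a number no higher from compound 2 to compound 4 (the limit leaves the size open) and it remains uncertain. For compound 4 the estimated value is 10000 nM with an expected range of 2500 nM to 30000 nM and another limit is the likeliest report.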

Compound 4, concentration for 50% growth inhibition: > 10000 nM
Compound 4: a limit, no number; the forecaster's own chance of this, stated with the estimate: 70%; the middle value sits exactly at the limit.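

In this assay compound 4 gives > 10000 nM, which is a limit, and compound 2 also stands at a limit, so no step can be read between them. The compounds shown leave open how strongly any of them inhibits growth, and which change would yield a measured number: the limit of > 10000 nM in this assay, at which 4 of the 4 values shown sit.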